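The source may report more compounds than this note shows. Statements on the series, on what has been measured and on what is new or still open speak of the compounds shown alone.

Compound 1, `CC1(c2ccccc2)CC(=O)N(CC(=O)N2CCC(Cc3ccccc3)CC2)C1=O`, and compound 2, `CC1(c2ccccc2)CC(=O)N(CC(=O)N2CCN(c3ccccc3)CC2)C1=O`, share one core and differ only in the ring attached to the amide. In a functional assay on the whole organism (strain CD-1) with Mus musculus as the target, in the maximal electroshock model, with a stated time of 2 h (on this read-out higher numbers stand for an effect only at larger amounts of compound and lower numbers for an effect already at smaller amounts), compound 1 gives 300 mg/kg. Compound 2, by contrast, gives "not active" (no number reported) in this assay, so no number exists for it and its standing can only be described as the absence of any recorded effect at the doses tried; there is no numeric gap between compound 1 and compound 2 to speak of.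

Compound 3, `CC1(c2ccccc2)CC(=O)N(CC(=O)N2CCN(c3ncccn3)CC2)C1=O`, has not been tested. It differs from compound 2 in one place: pyrimidin-2-yl in place of phenyl on an amine nitrogen in a ring. For the measured compounds named here, with no measured step available for this kind of change, the size and direction of any shift in this assay cannot be read from the data; the only anchors are compound 1, which gives a number, and compound 2, which gives none.

On these anchors, compound 3 is expected to be either without a recorded effect, like compound 2, or weak, near 300 mg/kg, estimated within 100 mg/kg to 1000 mg/kg.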

Compound 3, minimum effective dose: "not active" (no number reported)
No number was reported for compound 3, so the estimate cannot be set against anything.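

In this assay compound 2 gives "not active" (no number reported) and compound 3 gives "not active" (no number reported) with no number for either, so no step can be read between compound 2 and compound 3. No measurement shown here bears on this result. The compounds shown leave open whether pyrimidin-2-yl in place of phenyl alters the dose needed for an effect.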